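Removing One Methoxy from a Triazole Thioether

This account rests on a few compounds, and the source may have more. Where it says the series, first, only, none or still open, it means among the compounds named here.

In a functional assay on the whole organism (strain albino) for inhibition, with Rattus norvegicus as the target, read by paw edema, with a stated time of 2 h, at a dose of 0.28 mmol/kg by the oral route (a lower number here means less inhibition, a higher number more inhibition at the dose given (going by the name of the read-out)), compound 1 `COc1ccc(-c2nnc(SCC(=O)c3ccccc3)n2-c2ccccc2)cc1OC` gives 57%. Compound 2 `CCn1c(SCC(=O)c2ccccc2)nnc1-c1cc(OC)c(OC)c(OC)c1` stands lowest of the two numbers, since in this assay compound 2 gives 41%, a value that the higher reading of compound 1 exceeds by more than the usual scatter. Compound 3 `CCn1c(SCC(=O)c2ccccc2)nnc1-c1ccc(OC)c(OC)c1` differs from compound 2 in one place: hydrogen in place of methoxy on an aromatic carbon. Going by the values given here, no measured pair shows this change on its own, so the size of the step is open; a small shift in either direction, or none beyond the scatter, seems most likely. Compound 3 is therefore expected to give 45%, within 30% to 60%, an estimated step of a number 4 percentage points higher from compound 2 to compound 3 (within the scatter).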

Compound 3, a percentage reported as inhibition, in the whole organism at one dose (the size of the read-out at that dose, not a potency): 55%
Compound 3: middle estimate off by 10 percentage points, on the low side; measured number inside the range.
By their numbers in this assay, from the lowest: compound 2; then compounds 3 and 1 (each within the scatter of the next).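

In this assay, hydrogen in place of methoxy on this aromatic carbon gives a number 14 percentage points higher from compound 2 to compound 3 (beyond the scatter) and so shows that this position responds to the change. Ethyl in place of phenyl on the aromatic nitrogen gives a number 2 percentage points lower from compound 1 to compound 3 (within the scatter) and so does not separate those two groups at this dose. Nothing at hand explains the step at the methoxy position.

Still open, as far as these compounds go, is whether a hydroxyl or an amine on this aromatic carbon would read like hydrogen or like methoxy. Also open, from the compounds shown here alone, is whether the step holds with phenyl on the aromatic nitrogen.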